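Lengthening the Ester Chain a Second Time

A few compounds are considered here, and "the series" means these few. Any claim that something is new, unique, unknown or untested is made for them only; others in the source may bear on it.

Compound 1 `CCCCCCCOC(=O)CCC(=O)N1CCN(CCCOc2cc3c(Nc4ccc(F)c(Cl)c4)ncnc3cc2OC)CC1` gives 59.1% in a functional assay on A549 cells (Homo sapiens) for cytotoxicity, read by MTT assay, with a stated time of 24 h, tested at 40 uM; on this read-out lower numbers stand for a stronger effect and higher numbers for a weaker effect at the one concentration tested. Among the measured compounds shown here, compound 2 `CCCCCCCCCCCCOC(=O)CCC(=O)N1CCN(CCCOc2cc3c(Nc4ccc(F)c(Cl)c4)ncnc3cc2OC)CC1` gives 5.7% in this assay, the lowest of the two numbers measured, and the step of a number 53.4 percentage points lower from compound 1 to compound 2 (beyond the scatter) is the only comparison available. Compound 3 `CCCCCCCCCCCCCCCOC(=O)CCC(=O)N1CCN(CCCOc2cc3c(Nc4ccc(F)c(Cl)c4)ncnc3cc2OC)CC1` differs from compound 2 by propyl in place of hydrogen on a saturated chain carbon, ten or more bonds along the chain from an oxygen next to a carbonyl group. The earlier chain extension brought a large fall, yet compound 2 already sits near the bottom of the scale, leaving little room for another fall of that size; the step of a number 0.7 percentage points lower from compound 2 to compound 3 (within the scatter) is expected to stay within the scatter. For compound 3 the estimate in this assay is 5%, ranging from 0% to 22%.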

Compound 3, a percentage reported as activity, at one concentration (the size of the read-out at that concentration, not a potency): 85.5%
Compound 3: the middle estimate sits 80.5 percentage points below what was measured; the whole stated range lies below it.
By their numbers in this assay, from the lowest: compound 2; then compound 1; then compound 3.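

In this assay the further propyl on this chain carbon reverses the earlier direction: a number 79.8 percentage points higher from compound 2 to compound 3 (beyond the scatter) is a large rise that shows lengthening here does not keep lowering the number. The longest chain also ends up past the shortest one, with a number 26.4 percentage points higher from compound 1 to compound 3 (beyond the scatter) as a modest rise, so the lowest number belongs to the middle chain of compound 2 and compound 3 goes against any steady fall with length. Nothing measured here gives a reason for this turn. Where the turn falls between compound 2 and compound 3 stays open, as does whether a chain ending in an amine or a carboxylic acid would follow the same course.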